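Bromo for Methyl on a Low-Inhibition Scaffold

The compounds below may be only part of what the source reports. "The series", "measured", "known", "first", "only" and "open" are said of these compounds alone.

Of the compounds shown here, two of a shared core have been measured in a functional assay on the whole organism for inhibition, with Mus musculus as the target, with a stated time of 6 h, at a dose of 50 mg/kg by the oral route; a lower number here means less inhibition, a higher number more inhibition at the dose given (going by the name of the read-out). Compound 1, `Cc1ccc(-c2c(S(=O)(=O)c3ccccc3)cnc3cc(C)nn23)cc1`, gives 8.7%. Compound 2, `Cc1ccc(-c2c(S(=O)(=O)c3ccccc3)cnc3ncnn23)cc1`, gives 1.9%, the lowest of the two numbers shown; its nearest neighbour is compound 1, whose number lies higher by an amount that falls within the scatter of this assay, so the two compounds cannot be told apart on these data.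

Compound 3, `O=S(=O)(c1ccccc1)c1cnc2ncnn2c1-c1ccc(Br)cc1`, has not yet been measured in this assay. Its structure differs from that of compound 2 in one place: bromo in place of methyl on an aromatic carbon. Cut one bond further out, the change reads 4-methylphenyl to 4-bromophenyl, with the group placed para to a large group.

For the measured compounds named here, no measured pair in this set carries the same change, so the size of the step is not known from the data. Both measured compounds show little inhibition in this assay, and compound 3 is expected to stay in that region: the step from compound 2 to compound 3 is estimated as a number 6.1 percentage points higher from compound 2 to compound 3 (within the scatter), which is not expected to go beyond the scatter. Compound 3 is therefore estimated to give 8% in this assay, within a range from -5% to 25%.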

Compound 3, a percentage reported as inhibition, in the whole organism at one dose (the size of the read-out at that dose, not a potency): 0.9%
Beside the measured number, compound 3's estimate is 7.1 percentage points above it; the range from low to high includes it.
By their numbers in this assay, from the lowest: compounds 3, 2 and 1 (each within the scatter of the next).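

In this assay, for the compounds shown here, bromo in place of methyl on an aromatic carbon, para to a large group, gives the only step that can be read in this set: a number 1 percentage points lower from compound 2 to compound 3 (within the scatter). On the core of compound 2, the read-out therefore does not separate 4-methylphenyl from 4-bromophenyl, and with compound 2 at 1.9% and compound 3 at 0.9%, both stay in the region of little inhibition at the dose given, so this single exchange at this position does not lift the number out of the scatter. No measurement is available that could explain this result at this position.

On these data alone, it remains open whether a group of another kind at the same place, such as an amine or a carboxylic acid, would move the read-out in this assay beyond the scatter. As far as these compounds go, it is also open whether bromo in place of methyl would give a similar step on the core of compound 1, which gives 8.7% with the 4-methylphenyl group.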